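The compounds below may be only part of what the source reports. "The series", "measured", "known", "first", "only" and "open" are said of these compounds alone.

Compound 3 `COc1ccc(-c2cnc(NC(=O)c3ccc(F)cc3)[nH]2)cc1` is the starting point. In a toxicity assay on THP-1 cells (Homo sapiens) for inhibition (on this read-out higher numbers stand for lower toxicity in this test and lower numbers for higher toxicity in this test), compound 3 reaches only a limit, > 100000 nM, so no number is known for it. Its two neighbours differ from it only on the aromatic nitrogen of the shared core. Compound 1 `COc1ccc(-c2cnc(NC(=O)c3ccc(F)cc3)n2C)cc1` carries a methyl there, and in this assay compound 1 gives only a limit, >= 50000 nM. Compound 2 `COc1ccc(-c2cnc(NC(=O)c3ccc(F)cc3)n2C(C)C)cc1` carries an isopropyl there, and in this assay compound 2 likewise gives a limit, > 50000 nM. The steps a step that the two limits leave unreadable from compound 1 to compound 3 and a step that the two limits leave unreadable from compound 2 to compound 3 therefore carry no readable size. Compound 4 `COc1ccc(-c2cnc(NC(=O)c3ccc(F)cc3)n2-c2ccccc2)cc1` changes compound 3 by phenyl in place of hydrogen on an aromatic nitrogen. The measured steps offer no readable size, so a step of an at least 1.6-fold lower number from compound 3 to compound 4 (0.22 log units; that floor lies within the scatter) within the scatter is expected. The value of compound 4 is estimated at 60000 nM, between 15000 nM and 150000 nM.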

Compound 4, half-maximal cytotoxic concentration: 8800 nM
The estimate for compound 4 lay 6.8-fold (0.83 log units) above the measured number; measured number below the stated range.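

In this assay, within the data shown here, phenyl is the first group on this aromatic nitrogen to give a real number rather than a limit, with an at least 11-fold lower number from compound 3 to compound 4 (1.05 log units; beyond the scatter). Phenyl also gives a lower number than either small alkyl group, with an at least 5.6-fold lower number from compound 2 to compound 4 (0.75 log units; beyond the scatter) and an at least 5.6-fold lower number from compound 1 to compound 4 (0.75 log units; beyond the scatter), so toxicity in this test rises with this change. These sizes are only floors, because compound 3 stands at a limit: the limit of > 100000 nM in this assay, at which 1 of the 4 values shown sits.

As far as these compounds go, whether a cyclohexyl ring on this nitrogen would behave like phenyl stays open. So does the effect of a carboxylic acid on the added phenyl.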